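The source may report more compounds than this note shows. Statements on the series, on what has been measured and on what is new or still open speak of the compounds shown alone.

Compound 1 `O=C(c1cccc2ccccc12)n1c(C2CCC2)nc2ccccc21` gives > 10000 nM
Compound 2 `COc1ccc(C(=O)n2c(CC(C)C)nc3ccccc32)cc1` gives > 10000 nM

Both compounds were tested in a functional assay on cells (Homo sapiens) for cytotoxicity, read by MTT assay, with a stated time of 72 h (a lower number here means a stronger inhibitor, a higher number a weaker inhibitor), and neither result is a number. The evidence so far is the limit of > 10000 nM in this assay, at which 2 of the 2 values shown sit. From the compounds shown here alone, compound 2 stands at > 10000 nM, which is a limit of the assay, so its true position is unknown.

Compound 3 `COc1ccc(C(=O)n2c(C3CCCC3)nc3ccccc32)cc1` carries cyclopentyl in place of isobutyl on an aromatic carbon. For the measured compounds named here, no measured step shows what such an exchange does in this assay, so the expectation rests only on the two limits. Neither compound gives a number to start from, and no change beyond the scatter is expected. The estimated step is a number no higher from compound 2 to compound 3 (the limit leaves the size open). For compound 3 the expected value is 10000 nM, with an estimated range of 4000 nM to 25000 nM.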

Compound 3, half-maximal inhibitory concentration: > 10000 nM
Compound 3 ended at the assay's limit; the forecaster's own chance of this, stated with the estimate: 70%; the middle value sits exactly at the limit.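

For the compounds shown here, compound 2 and compound 3 both end at a limit of the assay, so the exchange of isobutyl for cyclopentyl gives no step that can be read. The compounds shown leave open the true value of each, and whether any change on the shared core would give a number.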